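Changing the side group on a shared core

The source may report more compounds than this note shows. Statements on the series, on what has been measured and on what is new or still open speak of the compounds shown alone.

Compound 1 (`COc1ccc(CN(C(=O)CSc2nc3ccc(OC)cc3s2)c2cc(OC)c(OC)c(OC)c2)cc1`) reads > 80000 nM as a limit
Compound 2 (`COc1ccc(CN(C(=O)CCSc2nc3ccccc3o2)c2cc(OC)c(OC)c(OC)c2)cc1`) reads 12600 nM as a number

Within the data shown here, in a functional assay on ECa-109 cells for antiproliferative activity against ECa-109 cell line (Homo sapiens), read by MTT assay, with a stated time of 48 h (on this read-out higher numbers stand for weaker inhibition and lower numbers for stronger inhibition), compound 2 gives 12600 nM as the only exact number so far. The reading of compound 1 is a limit and not a number. Compound 3 (`COc1ccc(CN(C(=O)CSc2nnnn2C)c2cc(OC)c(OC)c(OC)c2)cc1`) is still unmeasured and differs from compound 2 by (1-methyl-1H-tetrazol-5-yl)sulfanyl in place of ((1,3-benzoxazol-2-yl)sulfanyl)methyl on a saturated chain carbon bound to a carbonyl carbon in its structure. Among the measured compounds shown here, the one measured step (an at least 6.3-fold lower number from compound 1 to compound 2 (0.80 log units; beyond the scatter)) changed the same place and lies beyond the scatter. Going by that step, a somewhat smaller move towards weaker inhibition is expected (a 3.6-fold higher number from compound 2 to compound 3 (0.55 log units; beyond the scatter)). For compound 3 the estimated value is 45000 nM with an expected range (12000 nM to 150000 nM).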

Compound 3, half-maximal inhibitory concentration: 5540 nM
The estimate for compound 3 lay 8.1-fold (0.91 log units) above the measured number; the measured number lies below the stated range.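

In this assay, a single ring can replace the fused two-ring groups at this position without any loss of inhibition: 1-methyl-1H-tetrazol-5-yl gives a 2.3-fold lower number from compound 2 to compound 3 (0.36 log units; beyond the scatter). Set against the 6-methoxy-1,3-benzothiazol-2-yl group on the sulfur, the same ring gives an at least 14-fold lower number from compound 1 to compound 3 (1.15 log units; beyond the scatter). That larger step starts from a limit and not a number: the limit of > 80000 nM in this assay, at which 1 of the 3 values shown sits.

The step from compound 2 also shortens the chain, so the effect of the ring and the effect of the chain length remain unseparated. On these data alone, how an amine or a carboxylic acid would read on this saturated chain carbon also stays open.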